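Dimethoxyphenyl in place of dichlorophenyl on the carbonyl

This account rests on a few compounds, and the source may have more. Where it says the series, first, only, none or still open, it means among the compounds named here.

Compound 1 `COc1cc(-c2cc(/C=C/C(=O)c3ccc(Cl)c(Cl)c3)[nH]n2)cc(OC)c1OC` was tested in a functional assay on LOX IMVI cells (Homo sapiens) for cytotoxicity, read by sulforhodamine B assay, with a stated time of 48 h, tested at 10 uM (a lower number here means a stronger effect, a higher number a weaker effect of the compound at the concentration tested), where compound 1 gives 16%, the highest of the two numbers seen. Compound 2 `COc1ccc(-c2cc(/C=C/C(=O)c3ccc(N)cc3)[nH]n2)cc1OC` gives -66% in this assay, far lower than compound 1 and beyond the scatter. Compound 3 `COc1ccc(C(=O)/C=C/c2cc(-c3cc(OC)c(OC)c(OC)c3)n[nH]2)cc1OC` is not yet measured and differs from compound 1 in one place: 3,4-dimethoxyphenyl in place of 3,4-dichlorophenyl on a carbonyl carbon. Among the measured compounds shown here, no measured pair isolates this change. Since compound 2 reaches -66%, much lower numbers are known for this core. A modest downward step is therefore expected, a number 16 percentage points lower from compound 1 to compound 3 (beyond the scatter). Compound 3 is expected to give 0%, within -50% to 40%.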

Compound 3, a percentage reported as activity, at one concentration (the size of the read-out at that concentration, not a potency): -93%
For compound 3 the middle estimate is 93 percentage points above the measured one; measured number outside the range, below it.
By their numbers in this assay, from the lowest: compound 3; then compound 2; then compound 1.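

In this assay, the group on the carbonyl carbon proves decisive for the core of compound 1: 3,4-dimethoxyphenyl in place of 3,4-dichlorophenyl gives a large step, a number 109 percentage points lower from compound 1 to compound 3 (beyond the scatter) within a single change. Among the compounds shown here, this is the first pair that isolates this position, and it shows that two aromatic rings of the same kind, one carrying methoxy groups and one carrying chlorine, can separate widely. Nothing measured here accounts for the size of this step.

As far as these compounds go, it remains open whether a single methoxy group would give the same result as the two in compound 3. Also open, from the compounds shown here alone, is how a hydroxyl group or a carboxylic acid on this ring would compare.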